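This account rests on a few compounds, and the source may have more. Where it says the series, first, only, none or still open, it means among the compounds named here.

Measured compounds:
- Compound 1 `CCCC(C(C)C)n1ccc2cc(/C(C)=C/C(=O)Nc3ccccc3OCCCC(=O)O)ccc21` — 7.2 nM in an assay on Prostate gland for inhibition of steroid 5-alpha-reductase (Rattus norvegicus); a higher number here means a weaker inhibitor, a lower number a stronger inhibitor
- Compound 2 `C/C(=C\C(=O)Nc1ccc(F)cc1OCCCC(=O)O)c1ccc2c(ccn2C(c2ccccc2)c2ccccc2)c1` — 3.6 nM in this assay

Both compounds share the same core and were measured in this assay. Compound 2 gives the lower of the two numbers, but the gap to compound 1 is within the usual scatter of repeated measurements, so the two cannot be ranked against each other on these data alone.

Compound 3 `C/C(=C\C(=O)Nc1ccc(C)cc1OCCCC(=O)O)c1ccc2c(ccn2C(c2ccccc2)c2ccccc2)c1` has not yet been measured. It differs from compound 2 in a single place: methyl in place of fluoro on an aromatic carbon. Among the measured compounds shown here, no measured pair shows what such a swap does on this core, so there is no directly comparable step to lean on. The change is small in size, and both groups carry no donors or acceptors and no charge; on that basis the step is expected to stay within the scatter, with no clear direction. Compound 3 is therefore expected to land close to compound 2, at an estimated 4.5 nM in this assay, within a range of 1.5 nM to 13 nM. The step this implies, a 1.3-fold higher number from compound 2 to compound 3 (0.10 log units; within the scatter), is expected to be indistinguishable from repeat-measurement noise.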

Compound 3, half-maximal inhibitory concentration: 14 nM
Compound 3: the middle estimate sits 3.1-fold (0.49 log units) below what was measured, and the stated range ends below it.
By their numbers in this assay, from the lowest: compounds 2, 1 and 3 (each within the scatter of the next, the first and the last beyond it).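

Placing methyl in place of fluoro on the aromatic carbon that is para to a large group and meta to a 3-carboxypropoxy group gives a 3.9-fold higher number from compound 2 to compound 3 (0.59 log units; beyond the scatter) in this assay, so the number measured here does respond to which of these two groups this carbon carries. Among the compounds shown here, the step is modest, but it is the only step measured at this position, and it shows that a change of one heavy atom can be enough to exceed the scatter. Both groups count no hydrogen-bond donors or acceptors and no net charge, so these counts do not separate them, and no measurement here accounts for the difference.

The compounds shown leave open how other groups on this same carbon, such as chloro, methoxy or an amine, would compare with fluoro and methyl. They also leave open whether the same swap would give a step of similar size if the branched chain of compound 1 replaced the two phenyl rings of compound 2.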